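The compounds below may be only part of what the source reports. "The series", "measured", "known", "first", "only" and "open" are said of these compounds alone.

Measured compounds in a functional assay on K562 cells (Homo sapiens) for cytotoxicity, read by ELISA, with a stated time of 4 days; on this read-out lower numbers stand for stronger inhibition and higher numbers for weaker inhibition:
- compound 1 `Clc1cccc(-c2cc(-c3ccoc3)cc(-c3ccc(Cl)s3)n2)c1` gives 22100 nM
- compound 2 `Clc1ccc(-c2cc(-c3ccoc3)cc(-c3ccc(Cl)s3)n2)cc1` gives 19600 nM
- compound 3 `Cc1ccsc1-c1cc(-c2ccc(Cl)o2)cc(-c2cccc(Cl)c2)n1` gives 13400 nM

Compound 1 and compound 2 differ in one place, (4-chlorophenyl in place of 3-chlorophenyl on an aromatic carbon), and the step there was a 1.1-fold lower number from compound 1 to compound 2 (0.05 log units; within the scatter). Compound 4 `Cc1ccsc1-c1cc(-c2ccc(Cl)o2)cc(-c2ccc(Cl)cc2)n1` is not yet measured; it stands to compound 3 as compound 2 stands to compound 1, (4-chlorophenyl in place of 3-chlorophenyl on an aromatic carbon). The difference between the core of compound 3 and the core of compound 1 is not broken down here. The surroundings of the changed place differ as well: in compound 3 the place is meta to a 3-methylthiophen-2-yl group and meta to a 5-chlorofuran-2-yl group, in compound 1 meta to a 5-chlorothiophen-2-yl group and meta to a furan-3-yl group, so the two changes are of the same kind, not the same. Because compound 1 to compound 2 gave only a 1.1-fold lower number from compound 1 to compound 2 (0.05 log units; within the scatter), the step expected for compound 4 in this assay is a 1.1-fold lower number from compound 3 to compound 4 (0.05 log units; within the scatter). Compound 4 is therefore estimated at 12000 nM, with a likely range of 6000 nM to 25000 nM.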

Compound 4, half-maximal inhibitory concentration: 15600 nM
For compound 4 the middle estimate is 1.3-fold (0.11 log units) below the measured one; the range from low to high includes it.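

In this assay, 4-chlorophenyl in place of 3-chlorophenyl gave a 1.2-fold higher number from compound 3 to compound 4 (0.07 log units; within the scatter). Set beside the earlier pair, the change carries across the two cores as a step too small to read, with no difference between the cores: the same change on two cores in this assay, a 1.1-fold lower number (0.05 log units; within the scatter) from compound 1 to compound 2 and a 1.2-fold higher number (0.07 log units; within the scatter) from compound 3 to compound 4, 1.3-fold (0.12 log units) apart, within the scatter of two such steps This shows only that the change leaves the number within the scatter on these two cores; it gives the change no direction and says nothing of any other core.

Open, from the compounds shown here alone, is whether an amine or a carboxylic acid in place of the chlorine on the phenyl ring would move the number beyond the scatter. The two cores differ in more than one place, and what each of their groups contributes remains unresolved.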